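This account rests on a few compounds, and the source may have more. Where it says the series, first, only, none or still open, it means among the compounds named here.

Measured so far: compound 1 `COc1cc(OC)c(OC)cc1/C=C/C(=O)c1ccc(O)cc1O` with 37600 nM in a functional assay on HeLa cells (Homo sapiens) for inhibition, read by MTT assay, with a stated time of 72 h; on this read-out higher numbers stand for weaker inhibition and lower numbers for stronger inhibition; compound 2 `COc1cc(OC)c(OC)cc1/C=C/C(=O)c1ccc(Cl)c([N+](=O)[O-])c1` with 16500 nM.

Compound 2 stands lowest of the two numbers; compound 1, its nearest neighbour, gives a higher value, and that gap lies beyond the scatter. The next compound, compound 3 `COc1cc(OC)c(OC)cc1/C=C/C(=O)c1cccc([N+](=O)[O-])c1`, is reached from compound 2 by a change at one place: hydrogen in place of chloro on an aromatic carbon. Among the measured compounds shown here, no measured pair shows this change, so the step is expected to be small, most likely none beyond the scatter, with at most a slight loss of inhibition: a 1.3-fold higher number from compound 2 to compound 3 (0.12 log units; within the scatter). Compound 3 is therefore estimated at 22000 nM, with a range from 8000 nM to 55000 nM.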

Compound 3, half-maximal inhibitory concentration: 130000 nM
Beside the measured number, compound 3's estimate is 5.9-fold (0.77 log units) below it; measured number outside the range, above it.
By their numbers in this assay, from the lowest: compound 2; then compound 1; then compound 3.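

In this assay, the chloro group on this aromatic carbon, ortho to a nitro group and para to a large group, proves to matter: replacing it with hydrogen gives a 7.9-fold higher number from compound 2 to compound 3 (0.90 log units; beyond the scatter) and costs inhibition beyond the scatter. Among the compounds shown here, this is the first sign that inhibition depends on what occupies this position. Nothing measured here accounts for the size of the step. The compounds shown leave open whether a bromo, methyl or amine group here would match chloro. They also leave open whether chloro would have the same effect with an amine in place of the nitro group.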